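Swapping the Aryl Amide: From Compound 2 to Compound 3

This account rests on a few compounds, and the source may have more. Where it says the series, first, only, none or still open, it means among the compounds named here.

Of the compounds shown here, two have so far been measured in an assay on microsomes from liver for inhibition of sterol O-acyltransferase 1 (Rattus norvegicus); on this read-out higher numbers stand for weaker inhibition and lower numbers for stronger inhibition. Compound 1 `CCCCCCCCCCCCn1nnc(C(NC(=O)c2ccc(OC)cc2)c2ccccc2)n1` gives 600 nM in this assay, and compound 2 `CCCCCCCCCCCCn1nnc(C(NC(=O)c2cccc(Cl)c2)c2ccccc2)n1` gives 250 nM. Within the data shown here, compound 2 therefore holds the lowest of the two numbers, with compound 1 as its only neighbour. Among the measured compounds shown here, the single measured step, a 2.4-fold lower number from compound 1 to compound 2 (0.38 log units; beyond the scatter), came from putting a 3-chlorophenyl in place of a 4-methoxyphenyl on the carbonyl carbon.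

Compound 3 `CCCCCCCCCCCCn1nnc(C(NC(=O)c2ccnc(SC)c2)c2ccccc2)n1` has not yet been measured. It differs from compound 2 by a group of 8 heavy atoms (6 carbon, 1 nitrogen, 1 sulfur; one six-membered aromatic ring with 1 hetero atom) in place of a group of 7 heavy atoms (6 carbon, 1 chlorine; one six-membered aromatic ring of carbon only), on a carbonyl carbon. For the measured compounds named here, this is once more an exchange of the aromatic group on the carbonyl carbon, and the one step of that kind on record was modest. Going by the values given here, no measured pair shows what a six-membered aromatic ring with one hetero atom and a sulfur does at this position, so the direction is uncertain. A step of modest size, in either direction, is expected; the estimated change is a 1.6-fold higher number from compound 2 to compound 3 (0.20 log units; within the scatter). Compound 3 is thus expected to give 400 nM in this assay, with a range of 150 nM to 1200 nM.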

Compound 3, half-maximal inhibitory concentration: 80 nM
The estimate for compound 3 lay 5.0-fold (0.70 log units) above the measured number; measured number below the stated range.
By their numbers in this assay, from the lowest: compound 3; then compound 2; then compound 1.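

The aromatic group on the carbonyl carbon can hold a ring with a hetero atom and a sulfur and still give stronger inhibition in this assay, with a 3.1-fold lower number from compound 2 to compound 3 (0.49 log units; beyond the scatter). Compound 1 and compound 3 differ only in this group, and a 7.5-fold lower number from compound 1 to compound 3 (0.88 log units; beyond the scatter) shows that this one place alone can move the number well beyond the usual scatter, with everything else in the molecule held the same. The entering group also brings hydrogen-bond acceptors where the 3-chlorophenyl has none, but no measurement here links that count, or any other feature of the group, to the lower number.

The ring nitrogen and the sulfur enter together in compound 3, so the compounds shown leave open which of them, or whether only the two together, accounts for the step; a phenyl ring carrying a methylthio group would be one way of separating them. Also open, on these data alone, is how a methoxy group or an amine in place of the methylthio group would read here, and whether the gain holds with a shorter chain, such as octyl, in place of the dodecyl chain.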